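The source may report more compounds than this note shows. Statements on the series, on what has been measured and on what is new or still open speak of the compounds shown alone.

Working notes on the series. Compound 1 (`COc1ccc(/C=C/C2(C)C=CC(=O)O2)cc1OC`) is the reference point here. In a functional assay on K562 cells (Homo sapiens) for inhibition, read by sulforhodamine B assay, with a stated time of 48 h (a lower number here means a stronger inhibitor of growth, a higher number a weaker inhibitor of growth), compound 1 gives > 1000000 nM, which is a limit and not a number. Compound 2 (`COc1cc(/C=C/C2(C)C=CC(=O)O2)cc(OC)c1OC`) gives > 1000000 nM, again a limit. Both measured compounds therefore sit at the limit of > 1000000 nM in this assay, at which 2 of the 2 values shown sit, and compound 1 has no numeric position in the series.

The next compound is compound 3 (`COc1cccc(/C=C/C2(C)C=CC(=O)O2)c1`), where the change from compound 1 is hydrogen in place of methoxy on an aromatic carbon. For the measured compounds named here, the only measured step that bears on it is the same kind of exchange run the other way, a step that the two limits leave unreadable from compound 1 to compound 2. It offers no size to carry over, and no direction either. No step beyond the scatter can be argued from it, so compound 3 is expected to stay in the same region of this assay, most likely again reported as a limit. The step expected is a number no higher from compound 1 to compound 3 (the limit leaves the size open). For compound 3 the estimated value is 1000000 nM, with an expected range of 400000 nM to 2000000 nM.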

Compound 3, concentration for total growth inhibition: > 1000000 nM
Compound 3 gave a limit, no number; the forecaster's own chance of this, stated with the estimate: 85%; the middle value lies on the limit itself.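

In this assay compound 3, like compound 1, is reported only as a limit and not as a number, so no new step can be read between them: the limit of > 1000000 nM in this assay, at which 3 of the 3 values shown sit.

The compounds shown leave open whether methoxy or hydrogen on the aromatic carbon makes any difference to growth inhibition, in size or in direction.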